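The compounds below may be only part of what the source reports. "The series", "measured", "known", "first", "only" and "open" are said of these compounds alone.

compound 1 `O=C(Nc1ccc(NCC2CCCC2)cc1Cl)c1cc(Cl)ccc1O`: 21500 nM
compound 2 `O=C(Nc1ccc(NCc2ccncc2)cc1Cl)c1cc(Cl)ccc1O`: 65300 nM
compound 3 `O=C(Nc1ccc(NCc2ccc(Br)s2)cc1Cl)c1cc(Cl)ccc1O`: 20700 nM

All three values come from an ADME assay on A549 cells (Homo sapiens) for cytotoxicity, read by resazurin assay, with a stated time of 48 h; on this read-out higher numbers stand for lower toxicity in this test and lower numbers for higher toxicity in this test. Compound 3 shares the low end of the series with compound 1, and only compound 2 stands apart. Compound 4 `CC(C)(C)OC(=O)NCCNc1ccc(NC(=O)c2cc(Cl)ccc2O)c(Cl)c1` is the next to read: ((tert-butoxycarbonyl)amino)methyl in place of 5-bromothiophen-2-yl on a saturated chain carbon bound to a nitrogen on an aromatic ring, with ((tert-butoxycarbonyl)amino)methyl in place of 5-bromothiophen-2-yl on a saturated chain carbon bound to a nitrogen on an aromatic ring. The measured steps at this place are modest or smaller: a 3.0-fold higher number from compound 1 to compound 2 (0.48 log units; beyond the scatter), a 1.0-fold lower number from compound 1 to compound 3 (0.02 log units; within the scatter) and a 3.2-fold lower number from compound 2 to compound 3 (0.50 log units; beyond the scatter). Within the data shown here, no measured compound carries the entering group, so the expectation in this assay stays loose, leaning slightly upward and probably within the scatter. The expected step is a 1.4-fold higher number from compound 3 to compound 4 (0.16 log units; within the scatter). The estimate for compound 4 is 30000 nM, with an expected range of 14000 nM to 70000 nM.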

Compound 4, half-maximal cytotoxic concentration: 25000 nM
The estimate for compound 4 lay 1.2-fold (0.08 log units) above the measured number; the range from low to high includes it.
By their numbers in this assay, from the lowest: compounds 3, 1 and 4 (each within the scatter of the next); then compound 2.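

In this assay, the ((tert-butoxycarbonyl)amino)methyl group, which has no ring, reads level with the ring-bearing groups, with a 1.2-fold higher number from compound 3 to compound 4 (0.08 log units; within the scatter) and a 1.2-fold higher number from compound 1 to compound 4 (0.07 log units; within the scatter). Compound 2 remains the only one apart, with a 2.6-fold lower number from compound 2 to compound 4 (0.42 log units; beyond the scatter), so at this place the pyridin-4-yl group stands apart from a cyclopentyl group, a 5-bromothiophen-2-yl group and an open chain alike. No measurement at hand accounts for this reading. Still open, as far as these compounds go, is whether a free amine or a carboxylic acid on the same chain would read with compound 1, compound 3 and compound 4 or with compound 2.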